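Replacing the alkoxy arm of compound 1 with a difluorophenyl

A few compounds are considered here, and "the series" means these few. Any claim that something is new, unique, unknown or untested is made for them only; others in the source may bear on it.

Measured so far:
compound 1, `C[C@H](Oc1ccc(S(C)(=O)=O)cc1C(=O)N1Cc2cc(C(F)(F)F)cnc2C1)C(F)(F)F`, 0.4 mg/kg
compound 2, `C[C@H](Oc1ccc(S(C)(=O)=O)cc1C(=O)N1Cc2ccc(C3CCOCC3)cc2C1)C(F)(F)F`, 0.5 mg/kg

Both numbers come from a functional assay on the whole organism for inhibition, with Mus musculus as the target, with a stated time of 60 min; on this read-out higher numbers stand for an effect only at larger amounts of compound and lower numbers for an effect already at smaller amounts. Compound 1 gives 0.4 mg/kg and compound 2 gives 0.5 mg/kg; the two lie within the usual scatter of each other, so neither can be set apart from the other on this read-out, and the only firm statement is that both act at doses well below one unit of the scale.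

Compound 3, `CS(=O)(=O)c1ccc(-c2ccc(F)c(F)c2)c(C(=O)N2Cc3cc(C(F)(F)F)cnc3C2)c1`, is not yet measured. It differs from compound 1 in one place: 3,4-difluorophenyl in place of 1-(trifluoromethyl)ethoxy on an aromatic carbon. For the measured compounds named here, no pair of measured compounds shows a change of this kind, so there is no measured step to lean on, and the two measured compounds differ from each other elsewhere on the core.

The expected step from compound 1 to compound 3 in this assay is a 1.8-fold higher number from compound 1 to compound 3 (0.24 log units; within the scatter), that is, toward a higher dose but not clearly beyond the scatter. Compound 3 is estimated at 0.7 mg/kg, with a range from 0.2 mg/kg to 2.5 mg/kg.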

Compound 3, dose for 50% inhibition: 1 mg/kg
Estimate against measurement, compound 3: 1.4-fold (0.15 log units) below; the range from low to high includes it.
By their numbers in this assay, from the lowest: compounds 1, 2 and 3 (each within the scatter of the next, the first and the last beyond it).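

The position para to a methylsulfonyl group and ortho to a large group does not depend on the 1-(trifluoromethyl)ethoxy arm for effect in the whole organism. In this assay, 3,4-difluorophenyl in its place gives a 2.5-fold higher number from compound 1 to compound 3 (0.40 log units; beyond the scatter), a modest loss. Activity therefore survives without that arm's oxygen and defined stereocentre, though the arm holds the lower dose, and nothing measured on these compounds speaks to the reason for this step.

Open, on these data alone, is how an unfluorinated phenyl, a pyridine or a cyclic amine such as morpholine would fare at this position. Also open, as far as these compounds go, are whether a plain methoxy would hold the dose of compound 1, and whether the 3,4-difluorophenyl change would give a similar step on the core of compound 2.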